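Three Anilide Limits and a Shifted Methyl Pair

The source may report more compounds than this note shows. Statements on the series, on what has been measured and on what is new or still open speak of the compounds shown alone.

Measured compounds and their values in an ADME assay on MT4 cells (Homo sapiens) for cytotoxicity, read by MTT assay, with a stated time of 5 days; on this read-out higher numbers stand for lower toxicity in this test and lower numbers for higher toxicity in this test:
- compound 1, `Cc1ccc(NC(=O)CSc2snnc2-c2ccc(Br)cc2Br)c([N+](=O)[O-])c1`, gives > 229000 nM, a limit of the assay
- compound 2, `Cc1cccc(C)c1NC(=O)CSc1snnc1-c1ccc(Br)cc1Br`, gives >= 198000 nM, a limit of the assay
- compound 3, `CC(=O)c1ccc(NC(=O)CSc2snnc2-c2ccc(Br)cc2Br)c(Br)c1`, gives > 206000 nM, a limit of the assay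

Compound 2 stands where the other two stand: none of the three compounds returns a number in this assay, each only a limit. The limit of compound 2 is recorded as the limit of >= 198000 nM in this assay, at which 1 of the 3 values shown sits. The limit of compound 1 is recorded as the limit of > 229000 nM in this assay, at which 1 of the 3 values shown sits. The limit of compound 3 is recorded as the limit of > 206000 nM in this assay, at which 1 of the 3 values shown sits. Among the measured compounds shown here, nothing separates the three on these numbers, and no step between them can be sized.

Compound 4, `Cc1cccc(NC(=O)CSc2snnc2-c2ccc(Br)cc2Br)c1C`, differs from compound 2 by 2,3-dimethylphenyl in place of 2,6-dimethylphenyl on an amide-type nitrogen. Both dimethylphenyl groups carry the same count of atoms on the same amide-type nitrogen. With the three measured compounds all sitting at a limit, there is no basis for expecting a step in either direction beyond the scatter; compound 4 is expected to behave like compound 2, most probably again as a limit rather than a number. The expected step from compound 2 to compound 4 is a step that the limit leaves unreadable from compound 2 to compound 4. Compound 4 is therefore estimated at 200000 nM in this assay, within a range from 80000 nM to 400000 nM.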

Compound 4, half-maximal cytotoxic concentration: 241000 nM
Beside the measured number, compound 4's estimate is 1.2-fold (0.08 log units) below it, and the stated range covers the measured number.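

In this assay compound 4 gives 241000 nM as a number. Among the compounds shown here, compound 2 gives >= 198000 nM as a limit of the assay, so no step from compound 2 to compound 4 can be read. The compounds shown leave open whether any change of the group on the amide-type nitrogen shifts the half-maximal cytotoxic concentration at all.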